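The source may hold more compounds than are shown below. What is called first, only, known or untested is meant among the compounds shown, and "the series" means these compounds.

Measured so far:
Compound 1 `C/C=C1/[C@H](O[C@@H]2O[C@H](CO)[C@@H](O)[C@H](O)[C@H]2O)OC=C(C(=O)OC)[C@H]1CC(=O)OCc1ccco1`: > 15000 nM, a limit and not a number
Compound 2 `C/C=C1/[C@H](O[C@@H]2O[C@H](CO)[C@@H](O)[C@H](O)[C@H]2O)OC=C(C(=O)OC)[C@H]1CC(=O)OCCCCCCCCCCCCCCC`: 1600 nM
Compound 3 `C/C=C1/[C@H](O[C@@H]2O[C@H](CO)[C@@H](O)[C@H](O)[C@H]2O)OC=C(C(=O)OC)[C@H]1CC(=O)OCc1ccc2c(c1)OCCO2`: > 15000 nM, a limit and not a number

These compounds share one core and differ in a single group, and all were tested in a functional assay on SK-BR-3 cells (Homo sapiens) for antiproliferative activity, read by MTT assay, with a stated time of 72 h; a lower number here means a stronger inhibitor, a higher number a weaker inhibitor. In this assay, compound 3 gives > 15000 nM. From the compounds shown here alone, that is a limit, so its exact potency is unknown. Among the compounds with values here, compound 2, which carries a pentadecyl chain, is the only one with an actual number, 1600 nM.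

Compound 4 `C#CCOC(=O)C[C@@H]1C(C(=O)OC)=CO[C@@H](O[C@@H]2O[C@H](CO)[C@@H](O)[C@H](O)[C@H]2O)/C1=C/C` has not yet been measured. Going from compound 3 to compound 4, the change is ethynyl in place of 2,3-dihydro-1,4-benzodioxin-6-yl on a saturated chain carbon bound to an oxygen next to a carbonyl group. Cut one bond further out, this reads (2,3-dihydro-1,4-benzodioxin-6-yl)methyl to propargyl.

Within the data shown here, the one measured step of this kind is a step that the two limits leave unreadable from compound 1 to compound 3, so it offers no size to carry over. The best guide is the limit of > 15000 nM in this assay, at which 2 of the 3 values shown sit. Compound 4 has no long chain like that of compound 2, so it is expected to stay near that limit, with no clear direction of change. The expected step is a step that the limit leaves unreadable from compound 3 to compound 4. For compound 4 the estimated value is 20000 nM, with an expected range from 7000 nM to 40000 nM.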

Compound 4, half-maximal inhibitory concentration: > 15000 nM
Compound 4: only a limit was reported (the forecaster's own chance of this, stated with the estimate: 85%); the middle value lies beyond the limit too.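

In this assay compound 4 gives > 15000 nM, a limit and not a number, so its steps from compound 1 and from compound 3 cannot be read. The compounds shown leave open how far compound 1, compound 3 and compound 4 truly differ in potency, and whether any group besides the pentadecyl chain of compound 2 gives a measurable value.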